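Sulfonyl indole series: chloro to fluoro on the fused ring

A few compounds are considered here, and "the series" means these few. Any claim that something is new, unique, unknown or untested is made for them only; others in the source may bear on it.

Measured so far in an assay on HeLa cells for displacement of a labelled ligand from 5-hydroxytryptamine receptor 6 (Homo sapiens), with a stated time of 2 h; a higher number here means a weaker inhibitor, a lower number a stronger inhibitor:
- compound 1, `O=S(=O)(c1ccccc1)c1cn(C2CCNC2)c2ccccc12`, gives 5 nM
- compound 2, `O=S(=O)(c1cccc(F)c1)c1cn(C2CCNC2)c2ccc(Cl)cc12`, gives 15 nM
- compound 3, `CN1CCC(n2cc(S(=O)(=O)c3cccc4ccccc34)c3ccccc32)C1`, gives 6 nM

Compound 2 carries the highest of the three numbers in this assay. Its nearest neighbour is compound 3, and the gap between them lies beyond the usual scatter; the gap to compound 1 is wider still and also beyond the scatter. Compounds 1 and 3 sit close together, within the scatter of each other, so no order between them is claimed.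

The unmeasured compound 4, `O=S(=O)(c1cccc(F)c1)c1cn(C2CCNC2)c2ccc(F)cc12`, differs from compound 2 in one place: fluoro in place of chloro on an aromatic carbon. For the measured compounds named here, no measured pair in this set isolates that change, so the step has no direct precedent here. Exchange of one halogen for another at the same aromatic carbon, with no change in ring count, donors, acceptors or charge, is treated as a small change. Compound 4 is expected to give a number close to that of compound 2, with the step from compound 2 to compound 4 estimated at a 1.2-fold lower number from compound 2 to compound 4 (0.06 log units; within the scatter), that is, no shift beyond the scatter in either direction. Compound 4 is therefore estimated at 13 nM in this assay, with a range from 5 nM to 35 nM.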

Compound 4, inhibition constant: 9.6 nM
For compound 4 the middle estimate is 1.4-fold (0.13 log units) above the measured one; the measured number falls inside the stated range.
By their numbers in this assay, from the lowest: compounds 1, 3, 4 and 2 (each within the scatter of the next, the first and the last beyond it).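

In this assay, fluoro in place of chloro on this aromatic carbon, meta to a fused ring and para to a fused ring, gives a 1.6-fold lower number from compound 2 to compound 4 (0.19 log units; within the scatter), so the two halogens cannot be told apart at this carbon in this pair. For the compounds shown here, this is the first pair that isolates a single change at this position; compound 2 differs from compound 1 in more than one place, so the earlier compounds could not show what the halogen alone contributes. No measurement in hand bears on why this exchange leaves the number within the scatter.

From the compounds shown here alone, whether this tolerance extends beyond the two halogens remains open, with a methoxy group, a nitrile, a trifluoromethyl group or an amine on the same aromatic carbon as the obvious tests, and the same carbon carrying only hydrogen as the reference point. Also open, going by these compounds, is whether the chloro and fluoro pair would stay within the scatter on the core of compound 3, or alongside a different substituent on the sulfonyl aryl ring.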